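This account rests on a few compounds, and the source may have more. Where it says the series, first, only, none or still open, it means among the compounds named here.

Working notes on the series, read in a functional assay on HepG2 cells (Homo sapiens) for antiproliferative activity, read by CCK-8 assay, with a stated time of 72 h, tested at 2 uM; on this read-out lower numbers stand for a weaker effect and higher numbers for a stronger effect at the one concentration tested.

Compound 1 `COC(CCn1cnc2c(NCc3ccc(C(=O)Nc4ccccc4N)cc3)nc(Cl)nc21)OC` gives 8.52% in this assay. Compound 2 `CCCCn1cnc2c(NCc3ccc(C(=O)Nc4ccccc4N)cc3)nc(Cl)nc21` gives 6.8% in this assay. For the measured compounds named here, the only step between measured compounds is a number 1.7 percentage points lower from compound 1 to compound 2 (within the scatter), ethyl in place of dimethoxymethyl on a saturated chain carbon two bonds along the chain from an aromatic nitrogen. Compound 2 therefore stands at one end of a pair of numbers that lie within the scatter of each other; nothing separates compound 2 from compound 1 beyond the noise of the measurement.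

Compound 3 `Nc1ccccc1NC(=O)c1ccc(CNc2nc(Cl)nc3c2ncn3C2CCCC2)cc1` is not yet measured. Relative to compound 2 the change is cyclopentyl in place of butyl on an aromatic nitrogen. Going by the values given here, the one measured step, from compound 1 to compound 2, also altered the substituent on this aromatic nitrogen and left this assay unmoved within the scatter. Both measured numbers are low at the single concentration tested. The expected step is a number 1.2 percentage points higher from compound 2 to compound 3 (within the scatter), that is, none beyond the scatter. Compound 3 is estimated at 8%, with a range from 0% to 20% in this assay.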

Compound 3, a percentage reported as inhibition, at one concentration (the size of the read-out at that concentration, not a potency): 54.7%
Estimate against measurement, compound 3: 46.7 percentage points below, and the stated range ends below it.
By their numbers in this assay, from the lowest: compounds 2 and 1 (each within the scatter of the next); then compound 3.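

In this assay the substituent on the aromatic nitrogen proves to be a strong determinant of the reading: cyclopentyl in place of butyl gives a number 47.9 percentage points higher from compound 2 to compound 3 (beyond the scatter) and cyclopentyl in place of 3,3-dimethoxypropyl gives a number 46.2 percentage points higher from compound 1 to compound 3 (beyond the scatter) as well. The earlier change between the two open-chain groups gave only a number 1.7 percentage points lower from compound 1 to compound 2 (within the scatter) and so showed no such sensitivity at this position; among these three compounds, the one group with a ring is also the one that stands apart. The series offers no measurement that bears on the reason for this large step.

With a single ring at this position, the compounds shown leave open whether the ring itself matters or whether an open branched chain such as isopropyl would read the same, and how a smaller cyclopropyl, a larger cyclohexyl or a ring carrying an amine would compare. Since each reading comes from one concentration, the compounds shown also leave open how far the gap between compound 3 and the two open-chain compounds reflects a difference in potency.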